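A few compounds are considered here, and "the series" means these few. Any claim that something is new, unique, unknown or untested is made for them only; others in the source may bear on it.

The measured compounds in an ADME assay on KB cells (Homo sapiens) for cytotoxicity, read by MTT assay, with a stated time of 44 h (on this read-out higher numbers stand for weaker inhibition and lower numbers for stronger inhibition), are listed first.
Compound 1 `CCCCNC(=S)N/N=C\c1c[nH]c2ccccc12` gives > 100000 nM, which is a limit of this assay and not a number.
Compound 2 `Cc1ccccc1NC(=S)N/N=C\c1c[nH]c2ccccc12` gives > 100000 nM, again a limit.
Compound 3 `CC(C)CNC(=S)N/N=C\c1c[nH]c2ccccc12` gives > 100000 nM, again a limit.

Compound 3 therefore stands exactly where the other two stand: every value shown sits at the same limit (the limit of > 100000 nM in this assay, at which 3 of the 3 values shown sit), so no readable number exists for any of them. For the same reason none of the three steps between them can be sized: one is a step that the two limits leave unreadable from compound 1 to compound 2, another is a step that the two limits leave unreadable from compound 1 to compound 3, and the third is a step that the two limits leave unreadable from compound 2 to compound 3.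

Compound 4 `Cc1ccc(NC(=S)N/N=C\c2c[nH]c3ccccc23)cc1` has not yet been measured. Compared with compound 3 the change is a single one: 4-methylphenyl in place of isobutyl on an amide-type nitrogen. The measured step that comes closest to this exchange is a step that the two limits leave unreadable from compound 2 to compound 3. That step also swaps a methylphenyl group against a branched saturated chain on the same amide-type nitrogen, and it too is unreadable. With every measured value at the limit, there is no basis for expecting compound 4 to move off it. The step from compound 3 to compound 4 is therefore expected to be a step that the limit leaves unreadable from compound 3 to compound 4, meaning no readable change. For compound 4 the estimate is 200000 nM, with a range from 50000 nM to 1000000 nM, and most likely the assay will again report only a limit.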

Compound 4, half-maximal inhibitory concentration: > 100000 nM
Compound 4: only a limit was reported; the forecaster's own chance of this, stated with the estimate: 85%; the middle value does not contradict the limit.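

Within the data shown here, compound 4 gives only a limit in this assay and not a number, like compounds 1, 2 and 3, so no step from compound 4 to any of them can be read: the limit of > 100000 nM in this assay, at which 4 of the 4 values shown sit.

The compounds shown leave open how far apart these four truly lie, and whether any group on the amide-type nitrogen gives a readable number.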